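The compounds below may be only part of what the source reports. "The series", "measured", "known", "first", "only" and "open" are said of these compounds alone.

The two measured compounds:

Compound 1, `CCS(=O)(=O)Nc1cc(-c2ccc3ncnc(Nc4ccc(OC)cc4)c3c2)cnc1OC`, gives 1790 nM in a functional assay on MCF7 cells (Homo sapiens) for cytotoxicity, read by sulforhodamine B assay, with a stated time of 72 h; a lower number here means a stronger inhibitor, a higher number a weaker inhibitor.
Compound 2, `CCS(=O)(=O)Nc1cc(-c2ccc3ncnc(Nc4ccc(Cl)c(C(=O)OC)c4)c3c2)cnc1OC`, gives 1430 nM in this assay.

Both compounds share the same core and differ only in the ring carried on a nitrogen on an aromatic ring. Going by the values given here, the one step between them, a 1.3-fold lower number from compound 1 to compound 2 (0.10 log units; within the scatter), is within the scatter, so the two numbers cannot be told apart with confidence. Among the compounds with values here, compound 2 sits at one end of the two values, with compound 1 as its only neighbour.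

Compound 3, `CCS(=O)(=O)Nc1cc(-c2ccc3ncnc(Nc4ccc(C(=O)OC)c(OC)c4)c3c2)cnc1OC`, changes the same position once more: 3-methoxy-4-(methoxycarbonyl)phenyl in place of 4-chloro-3-(methoxycarbonyl)phenyl on a nitrogen on an aromatic ring. Within the data shown here, only one measured step bears on this change, the exchange of rings at this position from compound 1 to compound 2, and that step was a 1.3-fold lower number from compound 1 to compound 2 (0.10 log units; within the scatter). With a single comparison at this position, and that one within the scatter, there is no ground to expect a step beyond the scatter in this assay, and the expected change is a 1.0-fold higher number from compound 2 to compound 3 (0.02 log units; within the scatter). Compound 3 is therefore estimated at 1500 nM, with a range from 600 nM to 4000 nM.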

Compound 3, half-maximal inhibitory concentration: 10900 nM
Beside the measured number, compound 3's estimate is 7.3-fold (0.86 log units) below it, and the stated range ends below it.
By their numbers in this assay, from the lowest: compounds 2 and 1 (each within the scatter of the next); then compound 3.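

The ring on this nitrogen is not indifferent in this assay, although the earlier exchange of rings stayed within the scatter: with the 3-methoxy-4-(methoxycarbonyl)phenyl ring there is a 7.6-fold higher number from compound 2 to compound 3 (0.88 log units; beyond the scatter) and also a 6.1-fold higher number from compound 1 to compound 3 (0.78 log units; beyond the scatter) in the same direction. Having a methoxycarbonyl group on the ring does not settle the number, since compound 2 and compound 3 both carry one yet lie apart, so the way the groups are arranged on the ring, or the identity of the second group, must count here. Nothing measured in this set gives a reason for the weaker result of compound 3.

The step from compound 2 to compound 3 changes the ring in two ways at once, replacing chlorine with methoxy and shifting the methoxycarbonyl group, so these compounds cannot show which of the two changes carries the effect. On these data alone, it also remains open how a ring bearing a carboxylic acid or an amide in place of the methoxycarbonyl group would read in this assay at this position.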